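A few compounds are considered here, and "the series" means these few. Any claim that something is new, unique, unknown or untested is made for them only; others in the source may bear on it.

In an assay on isolated protein for inhibition of phosphodiesterase 4A (Sus scrofa) (a lower number here means a stronger inhibitor, a higher number a weaker inhibitor), compound 1 `COc1ccc(C(=O)Nc2c(F)cccc2Cl)cc1OC1CCCC1` gives 240 nM. Compound 2 `COc1ccc(C(=O)Nc2ccccc2C(F)(F)F)cc1OC1CCCC1` gives 3100 nM in this assay, the higher of the two numbers recorded so far. Compound 3 `COc1ccc(C(=O)Nc2ccccc2SC)cc1OC1CCCC1` differs from compound 2 in one place: methylsulfanyl in place of trifluoromethyl on an aromatic carbon, ortho to a large group. Within the data shown here, no measured pair shows this change, so its size is unknown from the data. The step of a 3.1-fold lower number from compound 2 to compound 3 (0.49 log units; beyond the scatter) is expected to lower the number, modestly but beyond the scatter. Compound 3 is therefore estimated at 1000 nM, with a range from 300 nM to 4000 nM.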

Compound 3, half-maximal inhibitory concentration: 1200 nM
Compound 3: the middle estimate sits 1.2-fold (0.08 log units) below what was measured; the measured number falls inside the stated range.
By their numbers in this assay, from the lowest: compound 1; then compound 3; then compound 2.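

In this assay, methylsulfanyl in place of trifluoromethyl on an aromatic carbon, ortho to a large group, gives a 2.6-fold lower number from compound 2 to compound 3 (0.41 log units; beyond the scatter), so the number at this position responds to the group placed there. The 2-(methylsulfanyl)phenyl of compound 3 still falls short of the 2-chloro-6-fluorophenyl of compound 1, with a 5.0-fold higher number from compound 1 to compound 3 (0.70 log units; beyond the scatter). No measurement shown here explains either step.

On these data alone, whether a methoxy group, an amine or a single chlorine in the same place would give a lower number than methylsulfanyl stays open. The compounds shown also cannot separate the effect of the sulfur atom from that of the smaller group.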